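This account rests on a few compounds, and the source may have more. Where it says the series, first, only, none or still open, it means among the compounds named here.

In a functional assay on QG-56 cells (Homo sapiens) for antiproliferative activity (on this read-out higher numbers stand for weaker inhibition and lower numbers for stronger inhibition), compound 1 `Cn1cncc1C(O)(c1ccc(C#N)cc1)c1cc2cc([N+](=O)[O-])cc(-c3cccc(C#N)c3)c2o1` gives 22.9 nM. Two further compounds on the shared core carry an amino group in place of the hydroxyl and a plain phenyl in place of the 3-cyanophenyl, and they differ from each other only in configuration: compound 2 `Cn1cncc1[C@](N)(c1ccc(C#N)cc1)c1cc2cc([N+](=O)[O-])cc(-c3ccccc3)c2o1` gives 206 nM and compound 3 `Cn1cncc1[C@@](N)(c1ccc(C#N)cc1)c1cc2cc([N+](=O)[O-])cc(-c3ccccc3)c2o1` gives 5.9 nM. Compound 1 thus stands between these two, with the second highest of the three numbers. Going by the values given here, the only step measured between compounds that differ in a single place is a 35-fold lower number from compound 2 to compound 3 (1.54 log units; beyond the scatter), a step that rests on the fact that compounds 2 and 3 differ only in the configuration as drawn and speaks to the configuration at the saturated carbon, not to any change on the aryl ring. Compound 4 `Cn1cncc1C(O)(c1ccc(C#N)cc1)c1cc2cc([N+](=O)[O-])cc(-c3ccccc3F)c2o1` differs from compound 1 in that (2-fluorophenyl in place of 3-cyanophenyl on an aromatic carbon). Among the compounds with values here, no measured step bears on a change of this kind, so the expectation for compound 4 in this assay this assay can only be anchored on compound 1, and no step beyond the scatter is expected in either direction. Compound 4 is therefore expected to give about 25 nM, within the range from 8 nM to 80 nM. That estimate means a 1.1-fold higher number from compound 1 to compound 4 (0.04 log units; within the scatter), a step expected to fall within the usual scatter.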

Compound 4, half-maximal inhibitory concentration: 89.5 nM
The estimate for compound 4 lay 3.6-fold (0.55 log units) below the measured number; the whole stated range lies below it.
By their numbers in this assay, from the lowest: compound 3; then compound 1; then compound 4; then compound 2.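

Going by these compounds alone, the aryl group on this aromatic carbon, meta to a nitro group, matters in this assay: 2-fluorophenyl in place of 3-cyanophenyl gives a 3.9-fold higher number from compound 1 to compound 4 (0.59 log units; beyond the scatter) and is the first measured change at this place, with the hydroxyl and the shared core held as in compound 1. The swap removes the nitrile, brings in fluorine and shifts the substituent around the phenyl ring all in one step, so the result cannot assign the change to any one of these. Within the data shown here, the only evidence to hand concerns configuration at the saturated carbon and offers no explanation for this step.

The compounds shown leave open whether the nitrile or the fluorine accounts for the difference, since 3-fluorophenyl, 2-cyanophenyl and plain phenyl do not appear here on the hydroxyl compounds. Also open, on these data alone, is how a carboxylic acid or an aminomethyl group on this phenyl ring would read in this assay and whether the same aryl change would act alike on the amino compounds, whose two configurations stand far apart.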